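From a dimethylphenyl to a methoxyphenyl sulfonamide

A few compounds are considered here, and "the series" means these few. Any claim that something is new, unique, unknown or untested is made for them only; others in the source may bear on it.

In a functional assay on MCF7 cells (Homo sapiens) for antiproliferative activity, read by sulforhodamine B assay, with a stated time of 48 h (on this read-out higher numbers stand for weaker inhibition and lower numbers for stronger inhibition), compound 1 `Cc1cc(C)cc(NS(=O)(=O)c2ccc(N3CCNC3=O)cc2)c1` gives 100 nM and compound 2 `Cc1ccc(NS(=O)(=O)c2ccc(N3CCNC3=O)cc2)c(C)c1` gives 230 nM on the same core. Compound 2 therefore holds the higher of the two numbers, which makes it the weaker inhibitor of this pair. Compound 3 `COc1ccc(NS(=O)(=O)c2ccc(N3CCNC3=O)cc2)cc1` has not yet been measured. Its structure follows from compound 2 by one change on the sulfonamide nitrogen: 4-methoxyphenyl in place of 2,4-dimethylphenyl on a sulfonamide nitrogen with 4-methoxyphenyl in place of 2,4-dimethylphenyl.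

Among the measured compounds shown here, no measured step introduces 4-methoxyphenyl, so the evidence is indirect. For the measured compounds named here, the only guide is the modest 2.3-fold higher number from compound 1 to compound 2 (0.36 log units; beyond the scatter) seen when 2,4-dimethylphenyl replaced 3,5-dimethylphenyl at this same place. A change here has thus moved the number only modestly, and a step of no greater size is expected, with a slight lean towards a higher number and little certainty about direction. The estimated step is a 1.3-fold higher number from compound 2 to compound 3 (0.12 log units; within the scatter) and may not clear the usual scatter. For compound 3 the expected value is 300 nM with an estimated range from 90 nM to 1000 nM in this measurement.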

Compound 3, half-maximal inhibitory concentration: > 1000 nM
Compound 3 was reported as a limit; the forecaster's own chance of this, stated with the estimate: 3%; middle value at least 3.3-fold (0.52 log units) away from the limit.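

In this assay compound 3 is reported as a limit and not as a number, > 1000 nM, so the steps that reach it give only a lower bound on their size: the limit of > 1000 nM in this assay, at which 1 of the 3 values shown sits.
Even so, the exchange of 2,4-dimethylphenyl for 4-methoxyphenyl gives an at least 4.3-fold higher number from compound 2 to compound 3 (0.63 log units; beyond the scatter) and the exchange of 3,5-dimethylphenyl for 4-methoxyphenyl gives an at least 10-fold higher number from compound 1 to compound 3 (1.00 log units; beyond the scatter), whereas the two dimethylphenyl compounds alone had shown only a 2.3-fold higher number from compound 1 to compound 2 (0.36 log units; beyond the scatter) as the reach of a change on the sulfonamide nitrogen.
This place is therefore not one of small changes only, and among the three compounds the 4-methoxyphenyl group is the one that leaves the measured range, while both dimethylphenyl groups stay inside it.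

The change to compound 3 swaps two methyl groups for one methoxy group in a single step, so the compounds shown cannot tell the loss of a methyl group from the entry of the oxygen. As far as these compounds go, a phenyl ring carrying a single methyl group, a chlorine or an amine on the sulfonamide nitrogen would separate these, and how far compound 3 really lies beyond its limit remains open.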